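Capping the amine of a fused cyano sulfonamide scaffold

The source may hold more compounds than are shown below. What is called first, only, known or untested is meant among the compounds shown, and "the series" means these compounds.

Compounds measured so far:
compound 1, `N#CC1=C(N)N(c2ccc(S(N)(=O)=O)cc2)C2=C(C(=O)CCC2)C1c1ccc(Cl)cc1Cl`, in a functional assay on Ehrlich cells (Mus musculus) for cytotoxicity, read by trypan blue exclusion, with a stated time of 2 h, tested at 100 ug/mL (a higher number here means a stronger effect of the compound at the concentration tested, a lower number a weaker effect), gives 95%
compound 2, `CC(Cl)CC(=O)NC1=C(C#N)C(c2ccc(Cl)cc2Cl)C2=C(CCCC2=O)N1c1ccc(S(N)(=O)=O)cc1`, in this assay gives 60%
compound 3, `Cc1ccc(C(=O)NC2=C(C#N)C(c3ccc(Cl)cc3Cl)C3=C(CCCC3=O)N2c2ccc(S(N)(=O)=O)cc2)cc1`, in this assay gives 40%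

Compound 2 stands second highest of the three numbers: a number 35 percentage points lower from compound 1 to compound 2 (beyond the scatter), while a number 20 percentage points lower from compound 2 to compound 3 (beyond the scatter). The unmeasured compound 4, `CN(C)c1ccc(/C=N/C2=C(C#N)C(c3ccc(Cl)cc3Cl)C3=C(CCCC3=O)N2c2ccc(S(N)(=O)=O)cc2)cc1`, changes compound 2 as follows: a group of 11 heavy atoms (9 carbon, 2 nitrogen; one six-membered aromatic ring of carbon only) in place of a group of 7 heavy atoms (4 carbon, 1 nitrogen, 1 oxygen, 1 chlorine; no ring), on a double-bonded ring carbon. Within the data shown here, the steps that bear on this are those from the free amine of compound 1 to its capped forms, a number 35 percentage points lower from compound 1 to compound 2 (beyond the scatter) and a number 55 percentage points lower from compound 1 to compound 3 (beyond the scatter), and the step between the two caps, a number 20 percentage points lower from compound 2 to compound 3 (beyond the scatter). Both caps lower the effect, the aromatic one more than the chain. Among the measured compounds shown here, compound 4 carries an aromatic cap, without a carbonyl and without a donor, which no measured compound shows directly. A modest decrease is therefore expected: a number 15 percentage points lower from compound 2 to compound 4 (beyond the scatter). The estimate for compound 4 is 45%, with a range from 25% to 70%.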

Compound 4, a percentage reported as activity, at one concentration (the size of the read-out at that concentration, not a potency): 40%
Compound 4: the middle estimate sits 5 percentage points above what was measured; measured number inside the range.
By their numbers in this assay, from the lowest: compounds 3 and 4 (each within the scatter of the next); then compound 2; then compound 1.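

At this position, on a double-bonded ring carbon, the drop in this assay does not depend on a carbonyl or on a hydrogen-bond donor in the cap: the group in compound 4 has neither, yet the data show a number 55 percentage points lower from compound 1 to compound 4 (beyond the scatter) as the free amine is replaced. Replacing the ((4-methylphenyl)carbonyl)amino group gives no change at the digits printed from compound 3 to compound 4 (within the scatter) despite the different link to the aromatic ring. Replacing the chain of ((2-chloropropyl)carbonyl)amino gives a number 20 percentage points lower from compound 2 to compound 4 (beyond the scatter) and so puts both aromatic caps shown under the chain cap.

Nothing available explains these steps. Still open, going by these compounds, is how a small acetyl cap or a plain methyl on the amine nitrogen would read here, and whether a carboxylic acid in place of the dimethylamino group would shift the number.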